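Ortho substituent on the benzyl group: fluoro to trifluoromethyl

The source may hold more compounds than are shown below. What is called first, only, known or untested is meant among the compounds shown, and "the series" means these compounds.

Measured compounds:
compound 2 `CCCCNc1nc(-c2ccccc2)nc2c1nnn2Cc1ccccc1` — 11 nM
compound 3 `CCCCNc1nc(-c2ccccc2)nc2c1nnn2Cc1ccccc1F` — 4.3 nM
compound 1 `CCNc1nc(-c2ccccc2)nc2c1nnn2Cc1ccccc1C(F)(F)F` — "not determined" (no result reported)

In an assay on Cerebral cortex for displacement of a labelled ligand from adenosine receptor A1 (Bos taurus) (a lower number here means a stronger inhibitor, a higher number a weaker inhibitor), compound 3 gives 4.3 nM, the lowest number of the two reported, and compound 2 gives 11 nM. Among the compounds with values here, the one measured step, a 2.6-fold lower number from compound 2 to compound 3 (0.41 log units; beyond the scatter), is a modest gain that lies beyond the scatter. Compound 1 carries the trifluoromethyl group on the shorter chain but has no result in this assay, so it offers no numbers to compare.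

Compound 4 `CCCCNc1nc(-c2ccccc2)nc2c1nnn2Cc1ccccc1C(F)(F)F` differs from compound 3 by trifluoromethyl in place of fluoro on an aromatic carbon. Within the data shown here, no measured step covers this exchange; the only step that touches the same position, from compound 2 to compound 3, concerns putting fluoro in place of hydrogen, and nothing shows what a larger group at that position does. The expectation is therefore a step near zero, within the scatter, with the wide range reflecting the lack of a direct comparison: for compound 4 in this assay the estimate is 6 nM (2 nM to 20 nM), which corresponds to an expected step of a 1.4-fold higher number from compound 3 to compound 4 (0.14 log units; within the scatter).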

Compound 4, inhibition constant: 6.5 nM
Compound 4: the middle estimate sits 1.1-fold (0.03 log units) below what was measured; the range from low to high includes it.
By their numbers in this assay, from the lowest: compounds 3, 4 and 2 (each within the scatter of the next, the first and the last beyond it).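

In this assay, within the data shown here, the position takes trifluoromethyl as well as fluoro, and the exchange gives no step that stands clear of the scatter (a 1.5-fold higher number from compound 3 to compound 4 (0.18 log units; within the scatter)). The comparison with hydrogen also stays within the scatter (a 1.7-fold lower number from compound 2 to compound 4 (0.23 log units; within the scatter)), so compound 4 cannot be separated from either neighbour, although the fluoro step alone lies beyond it (a 2.6-fold lower number from compound 2 to compound 3 (0.41 log units; beyond the scatter)). No available evidence bears on this result.

As far as these compounds go, whether the position also accepts a methoxy group, an amine or a carboxylic acid remains open. With no number for compound 1, the effect of the shorter chain alongside trifluoromethyl cannot be read.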